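Quinolinyl amide replacing ortho-methylbenzamide on a quinoline core

The compounds below may be only part of what the source reports. "The series", "measured", "known", "first", "only" and "open" are said of these compounds alone.

Measured so far:
compound 1 `CCN1CCN(c2cc(C)c3cc(NC(=O)c4ccccc4C)ccc3n2)CC1` — 29200 nM
compound 2 `Cc1cc(NCCN2CCN(C)CC2)nc2ccc(NC(=O)c3ccc(Cl)c(Cl)c3)cc12` — 2690 nM

In a functional assay on SK-BR-3 cells (Homo sapiens) for antiproliferative activity, read by MTT assay, with a stated time of 72 h (a lower number here means a stronger inhibitor, a higher number a weaker inhibitor), compound 1 gives 29200 nM and stands as the higher of the two numbers; compound 2 gives 2690 nM, a gap that is beyond the scatter. The two differ in several places, so nothing is attributed to any single change.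

Compound 3 `CCN1CCN(c2cc(C)c3cc(NC(=O)c4ccc5ccccc5n4)ccc3n2)CC1` is not yet measured in this assay. Relative to compound 1 the change is quinolin-2-yl in place of 2-methylphenyl on a carbonyl carbon. Among the compounds with values here, no comparable step is known, so the direction is uncertain; a modest move toward lower numbers is expected, a 2.9-fold lower number from compound 1 to compound 3 (0.47 log units; beyond the scatter), roughly the expected size. Compound 3 is estimated at 10000 nM, within 3000 nM to 35000 nM.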

Compound 3, half-maximal inhibitory concentration: 3760 nM
The estimate for compound 3 lay 2.7-fold (0.42 log units) above the measured number, within the range that was stated.
By their numbers in this assay, from the lowest: compounds 2 and 3 (each within the scatter of the next); then compound 1.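

Notes on the substituent on a carbonyl carbon whose other neighbour is the amide-type nitrogen: in this assay this is the first comparison in the series that differs in one place, and quinolin-2-yl in place of 2-methylphenyl gives (a 7.8-fold lower number from compound 1 to compound 3 (0.89 log units; beyond the scatter)). The number at this position therefore depends on the group carried there. No measurement bears on the reason for this step.

From the compounds shown here alone, whether an unsubstituted phenyl at this position would fall nearer compound 1 or compound 3 remains open. Going by these compounds, the effect of an amine on the quinolin-2-yl also remains open.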